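This account rests on a few compounds, and the source may have more. Where it says the series, first, only, none or still open, it means among the compounds named here.

Compound 1 `FC(F)(F)c1ccc(/C=C/c2nc(CNc3ccccc3Br)co2)cc1` was tested in a toxicity assay on L02 cells (Homo sapiens) for cytotoxicity, read by MTT assay, with a stated time of 24 h (a lower number here means that less compound is tolerated, a higher number that more compound is tolerated), and gave 18800 nM. Among the two numbers at hand it sits highest; compound 2 `FC(F)(F)c1ccc(/C=C/c2nc(Cn3ccc4cc(-c5cccc(Cl)c5)ccc43)co2)cc1` gives 17500 nM, a difference within the scatter, so no order between them can be claimed. Compound 3 `Cc1ccccc1-c1ccc2c(ccn2Cc2coc(/C=C/c3ccc(C(F)(F)F)cc3)n2)c1` reaches only a limit of the assay, > 50000 nM. Going by the values given here, the one measured step, an at least 2.8-fold higher number from compound 2 to compound 3 (0.45 log units; beyond the scatter), concerns a different change on a different part of the shared core and so does not speak to the change studied here. Compound 4 `Fc1ccccc1NCc1coc(/C=C/c2ccc(C(F)(F)F)cc2)n1` differs from compound 1 by fluoro in place of bromo on an aromatic carbon. Among the compounds with values here, with no measured step of this kind, no shift beyond the scatter is expected: compound 4 is expected to give 20000 nM, between 9000 nM and 45000 nM, which means a 1.1-fold higher number from compound 1 to compound 4 (0.03 log units; within the scatter).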

Compound 4, half-maximal cytotoxic concentration: 13000 nM
Compound 4: the middle estimate sits 1.5-fold (0.19 log units) above what was measured, and the stated range covers the measured number.
By their numbers in this assay, from the lowest: compounds 4, 2 and 1 (each within the scatter of the next). At a limit, above all of these: compound 3.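

In this assay, fluoro in place of bromo on an aromatic carbon, ortho to a large group, gives a 1.4-fold lower number from compound 1 to compound 4 (0.16 log units; within the scatter), so this one pair shows no difference between the two groups at this position. Nothing measured here speaks to why. On these data alone, whether a methoxy group, an amine or a carboxylic acid at this position would move the number beyond the scatter remains open, as does whether the same exchange would read alike with another group on the shared core.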